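The source may hold more compounds than are shown below. What is called first, only, known or untested is meant among the compounds shown, and "the series" means these compounds.

In an ADME assay on HEK293 cells (Homo sapiens) for cytotoxicity, with a stated time of 72 h (a higher number here means that more compound is needed for the effect, a lower number that less compound is needed), compound 1 `C=C[C@@](C)(/C=C/c1ccc(O)cc1)CCC1OC1(C)C` gives > 36600 nM, which is a limit of the assay and not a number. Compound 2 `C=C[C@@](C)(/C=C/c1ccc(O)cc1)CCCO` gives > 36600 nM, which is also a limit. Compound 2 therefore has no exact value, and the data hold only (the limit of > 36600 nM in this assay, at which 2 of the 2 values shown sit).

Compound 3 `C=C[C@@](C)(/C=C/c1ccc(O)cc1)CC/C=C/C#N` comes from compound 2 through one change: 2-cyanoethenyl in place of hydroxymethyl on a saturated chain carbon, three bonds along the chain from two double-bonded chain carbons. In words, 2-cyanoethenyl stands in place of hydroxymethyl on a saturated chain carbon, three bonds along the chain from two double-bonded chain carbons.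

Going by the values given here, the one measured step at this place is a step that the two limits leave unreadable from compound 1 to compound 2, so it gives no size to carry over and points in neither direction. The expected result is therefore no clear change beyond the scatter. The estimated change is a step that the limit leaves unreadable from compound 2 to compound 3. Compound 3 is expected near 40000 nM, with an estimated range from 15000 nM to 100000 nM.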

Compound 3, half-maximal effective concentration: > 36600 nM
Compound 3 was reported as a limit (the forecaster's own chance of this, stated with the estimate: 70%); the middle value does not contradict the limit.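

No step from compound 1 or compound 2 to compound 3 can be read, since each value is a limit of the assay and not a number: the limit of > 36600 nM in this assay, at which 3 of the 3 values shown sit.

The compounds shown leave open how much of each is needed for the effect in this assay, and so whether swapping these chain groups makes any difference.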